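Methoxy for methyl on the pendant phenyl of compound 3

The compounds below may be only part of what the source reports. "The series", "measured", "known", "first", "only" and "open" are said of these compounds alone.

Compound 3 `Cc1cccc(-c2c(-c3ccc(F)cc3)nc(C(F)(F)F)n2CC[C@@H](O)C[C@@H](O)CC(=O)O)c1` gives 74 nM in an assay on microsomes from liver for inhibition of 3-hydroxy-3-methylglutaryl-coenzyme A reductase (Rattus norvegicus) (on this read-out higher numbers stand for weaker inhibition and lower numbers for stronger inhibition), the second highest of three numbers. Compound 1 `O=C(O)C[C@H](O)C[C@H](O)CCn1c(C(F)(F)F)nc(-c2ccc(F)cc2)c1-c1ccc(F)cc1` gives 38 nM in this assay, and compound 2 `O=C(O)C[C@H](O)C[C@H](O)CCn1c(C(F)(F)F)nc(-c2ccc(F)cc2)c1-c1ccccc1` gives 201 nM. The steps are a 1.9-fold higher number from compound 1 to compound 3 (0.29 log units; within the scatter), a 2.7-fold lower number from compound 2 to compound 3 (0.43 log units; beyond the scatter) and a 5.3-fold higher number from compound 1 to compound 2 (0.72 log units; beyond the scatter).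

Compound 4 `COc1cccc(-c2c(-c3ccc(F)cc3)nc(C(F)(F)F)n2CC[C@@H](O)C[C@@H](O)CC(=O)O)c1` differs from compound 3 by methoxy in place of methyl on an aromatic carbon. Going by the values given here, no measured step exchanges methyl for methoxy; the bearing steps are the substituent changes on the same ring, a 2.7-fold lower number from compound 2 to compound 3 (0.43 log units; beyond the scatter) and a 5.3-fold higher number from compound 1 to compound 2 (0.72 log units; beyond the scatter), both modest. For compound 4 a small step is therefore expected, a 1.5-fold higher number from compound 3 to compound 4 (0.17 log units; within the scatter), toward a slightly higher number in this assay, with the direction not secured. Compound 4 is estimated at 110 nM, range 45 nM to 270 nM.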

Compound 4, half-maximal inhibitory concentration: 135 nM
The estimate for compound 4 lay 1.2-fold (0.09 log units) below the measured number; low and high end bracket the measured number.
By their numbers in this assay, from the lowest: compounds 1, 3, 4 and 2 (each within the scatter of the next, the first and the last beyond it).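

In this assay, methoxy on this aromatic carbon cannot be separated from methyl (a 1.8-fold higher number from compound 3 to compound 4 (0.26 log units; within the scatter)) or from hydrogen (a 1.5-fold lower number from compound 2 to compound 4 (0.17 log units; within the scatter)). Methyl, by contrast, stands clear of hydrogen (a 2.7-fold lower number from compound 2 to compound 3 (0.43 log units; beyond the scatter)), so the gain seen with methyl does not clearly carry over to methoxy. The 3-methoxyphenyl remains separated from the 4-fluorophenyl (a 3.6-fold higher number from compound 1 to compound 4 (0.55 log units; beyond the scatter)).

Open, on these data alone, is whether an amine, a carboxylic acid or a longer ether chain at this place would move the number beyond the scatter from compound 3. The data offer no explanation for the size of these steps.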